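Adding a Second Chloro Group to Compound 2

This account rests on a few compounds, and the source may have more. Where it says the series, first, only, none or still open, it means among the compounds named here.

Of the compounds shown here, two with a shared core have been measured in an ADME assay on Vero cells (Chlorocebus sabaeus) for inhibition; a higher number here means that more compound is tolerated, a lower number that less compound is tolerated. Compound 1 (`O=C1/C(=C/c2c(Cl)cccc2Cl)CCC/C1=C\c1c(Cl)cccc1Cl`) gives 574000 nM, and compound 2 (`COc1ccc(/C=C2\CCC/C(=C\c3ccccc3Cl)C2=O)cc1`) gives 238000 nM. Compound 2 therefore holds the lower of the two numbers, and the gap between them lies beyond the usual scatter. These two compounds differ in more than one place, so no single structural change can be read from their values.

Compound 3 (`COc1ccc(/C=C2\CCC/C(=C\c3c(Cl)cccc3Cl)C2=O)cc1`) has not yet been measured. It departs from compound 2 by one change, chloro in place of hydrogen on an aromatic carbon, which turns 2-chlorophenyl into 2,6-dichlorophenyl. Within the data shown here, the only guide is compound 1, which carries the 2,6-dichlorophenyl group and gives 574000 nM, the higher number of the pair. A small upward move in this assay is therefore expected, probably within the scatter, though two compounds make this a weak basis. The expected change is a 1.4-fold higher number from compound 2 to compound 3 (0.14 log units; within the scatter). For compound 3 the estimated value is 330000 nM, with an expected range from 140000 nM to 700000 nM.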

Compound 3, half-maximal cytotoxic concentration: 232000 nM
Beside the measured number, compound 3's estimate is 1.4-fold (0.15 log units) above it; low and high end bracket the measured number.
By their numbers in this assay, from the lowest: compounds 3 and 2 (each within the scatter of the next); then compound 1.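

In this assay, the step that adds a second chloro group, turning 2-chlorophenyl into 2,6-dichlorophenyl on the 4-methoxyphenyl-bearing core, reads a 1.0-fold lower number from compound 2 to compound 3 (0.01 log units; within the scatter) and so lies within the scatter: at this position, with this partner, compound 2 and compound 3 cannot be told apart. The step that does exceed the scatter is a different one, a 2.5-fold lower number from compound 1 to compound 3 (0.39 log units; beyond the scatter) with 4-methoxyphenyl in place of 2,6-dichlorophenyl, a modest move that could not be isolated while only the first two compounds, which differ in more than one place, stood side by side. Within this small set, then, the number responds to the exchange of 4-methoxyphenyl for 2,6-dichlorophenyl and not to the added chloro group, although nothing available explains either result.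

From the compounds shown here alone, what remains open is whether this position would stay as silent with a different group in place of the chloro group, such as an amine or a carboxylic acid. Also open, going by these compounds, is whether the added chloro group would stay without consequence if the 4-methoxyphenyl group carried a longer chain.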